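Methyl on the Saturated Ring: A Second Small Change

A few compounds are considered here, and "the series" means these few. Any claim that something is new, unique, unknown or untested is made for them only; others in the source may bear on it.

Compound 1 `COc1cc2c(Oc3ccc(NC(=O)c4nnn(-c5ccccc5C)c4C)cc3F)ccnc2cc1OCCCN1CCCC1` and compound 2 `COc1cc2c(Oc3ccc(NC(=O)c4nnn(-c5ccccc5C)c4C)cc3F)ccnc2cc1OCCCN1CCCCC1` share one core and differ in a single place. In a functional assay on HT-29 cells (Homo sapiens) for cytotoxicity, read by MTT assay, with a stated time of 72 h (on this read-out higher numbers stand for weaker inhibition and lower numbers for stronger inhibition), compound 1 gives 450 nM, and in this assay compound 2 gives 450 nM. The step of no change at the digits printed from compound 1 to compound 2 (within the scatter) shows that piperidin-1-yl in place of pyrrolidin-1-yl leaves the read-out where it stood, so compound 2 is level with compound 1 on the numbers in hand. Compound 3 `COc1cc2c(Oc3ccc(NC(=O)c4nnn(-c5ccccc5C)c4C)cc3F)ccnc2cc1OCCCN1CCC(C)CC1` is not yet measured; it differs from compound 2 by methyl in place of hydrogen on a saturated ring carbon, a change that reads piperidin-1-yl to 4-methylpiperidin-1-yl. Among the measured compounds shown here, the only measured step that bears on it is no change at the digits printed from compound 1 to compound 2 (within the scatter), which was flat, and the new change again touches only the same six-membered non-aromatic ring with one nitrogen. Compound 3 is therefore expected to show no change at the digits printed from compound 2 to compound 3 (within the scatter), a step not beyond the scatter. The estimate for compound 3 in this assay is 450 nM, expected to lie between 200 nM and 1000 nM.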

Compound 3, half-maximal inhibitory concentration: 520 nM
Estimate against measurement, compound 3: 1.2-fold (0.06 log units) below, and the stated range covers the measured number.
By their numbers in this assay, from the lowest: compounds 1, 2 and 3 (each within the scatter of the next).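

In this assay, putting methyl on the saturated ring carbon three ring bonds from the ring nitrogen gives a 1.2-fold higher number from compound 2 to compound 3 (0.06 log units; within the scatter). The earlier pair had changed only the size of the saturated ring, whereas this result shows that the piperidin-1-yl ring can also carry a methyl at this carbon without a step beyond the scatter. The two changes together, 4-methylpiperidin-1-yl in place of pyrrolidin-1-yl, give a 1.2-fold higher number from compound 1 to compound 3 (0.06 log units; within the scatter), and no supporting measurement accompanies these values to account for them.

The compounds shown leave open whether a hydroxyl, a carboxylic acid or a phenyl group on this same ring carbon would stay as flat. They also leave open whether a morpholin-4-yl ring in place of the piperidin-1-yl ring, or a longer chain to the ring nitrogen, would do so.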